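Working notes: aromatic ring substitution, compound 1 to compound 3

The compounds below may be only part of what the source reports. "The series", "measured", "known", "first", "only" and "open" are said of these compounds alone.

Compound 1 `CC#CCn1c(N2CCC[C@@H](N)C2)cc(=O)n(Cc2ccccc2C(=O)O)c1=O` is the reference point of the series. In an ADME assay on Sf9 cells for inhibition of Dipeptidyl peptidase 9 (Homo sapiens), read by fluorescence, with stated times of 60 s and 20 min (on this read-out higher numbers stand for weaker inhibition and lower numbers for stronger inhibition), compound 1 gives only a limit of the assay, > 100000 nM. Among the compounds with values here, the single measured comparison is compound 2 `CC#CCn1c(N2CCC[C@@H](N)C2)cc(=O)n(Cc2ccc(Cl)cc2C(=O)O)c1=O`, which carries a chloro in place of hydrogen on an aromatic carbon. In this assay compound 2 likewise gives only a limit, > 100000 nM. The step that the two limits leave unreadable from compound 1 to compound 2 therefore cannot be read, since (the limit of > 100000 nM in this assay, at which 2 of the 2 values shown sit). Compound 1 thus stands at the limit, with no numeric value to place it against.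

Compound 3 `CC#CCn1c(N2CCC[C@@H](N)C2)cc(=O)n(Cc2cc(C#N)ccc2C(=O)O)c1=O` is not yet measured. Its change from compound 1 is cyano in place of hydrogen on an aromatic carbon. Within the data shown here, the only step that bears on it is a step that the two limits leave unreadable from compound 1 to compound 2, which has no readable size; no other measured compound varies this ring. With both known values at the limit, the expectation in this assay is no readable movement and most likely another limit. Compound 3 is therefore expected to give 200000 nM, within 50000 nM to 1000000 nM. The step that the limit leaves unreadable from compound 1 to compound 3 is the estimated change, and it is expected to remain unreadable.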

Compound 3, half-maximal inhibitory concentration: > 100000 nM
Compound 3: no number, only a limit (the forecaster's own chance of this, stated with the estimate: 85%); the middle value does not contradict the limit.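

No new step can be read between compound 1 and compound 3 in this assay, since both give only a limit: the limit of > 100000 nM in this assay, at which 3 of the 3 values shown sit. Still open, going by these compounds, are the numeric potencies of compound 1, compound 2 and compound 3, and whether chloro or cyano in place of hydrogen on an aromatic carbon moves the inhibition at all.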